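The source may hold more compounds than are shown below. What is called first, only, known or untested is meant among the compounds shown, and "the series" means these compounds.

Compound 1, `CC1CCN(c2c(S(=O)(=O)c3ccc(Cl)c(Cl)c3)cnc3cc(F)ccc23)CC1`, gives 94% in an assay on isolated protein for displacement of a labelled ligand from metabotropic glutamate receptor 5 (Homo sapiens), with a stated time of 60 min, tested at 1 uM; a lower number here means less inhibition, a higher number more inhibition at the concentration tested (going by the name of the read-out). Compound 2, `COc1ccc(S(=O)(=O)c2cnc3cc(F)ccc3c2N2CCC(C)CC2)cc1`, gives 90% in this assay.

Compound 2 stands lowest of the two numbers, nearest compound 1 with a number 4 percentage points lower from compound 1 to compound 2 (within the scatter). Compound 3, `Cc1ccc(S(=O)(=O)c2cnc3cc(F)ccc3c2N2CCC(C)CC2)cc1Cl`, differs from compound 2 by 3-chloro-4-methylphenyl in place of 4-methoxyphenyl on a sulfonyl sulfur. Among the measured compounds shown here, the one measured step on this sulfonyl-linked aryl, a number 4 percentage points lower from compound 1 to compound 2 (within the scatter), lies within the scatter, so the aryl group here has so far moved the read-out little. No step beyond the scatter is therefore expected in this assay, with a number 2 percentage points higher from compound 2 to compound 3 (within the scatter). Compound 3 is estimated at 92%, between 80% and 99%.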

Compound 3, a percentage reported as inhibition, at one concentration (the size of the read-out at that concentration, not a potency): 93%
Compound 3: the middle estimate sits 1 percentage points below what was measured, within the range that was stated.
By their numbers in this assay, from the lowest: compounds 2, 3 and 1 (each within the scatter of the next).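

In this assay, 3-chloro-4-methylphenyl, which has no hydrogen-bond acceptor, in place of 4-methoxyphenyl, which has one, gives a number 3 percentage points higher from compound 2 to compound 3 (within the scatter). Methyl in place of chloro on an aromatic carbon gives a number 1 percentage points lower from compound 1 to compound 3 (within the scatter), so a second kind of change on this sulfonyl-linked aryl also stays within the scatter. No measurement here bears on a reason for these results.

Open, going by these compounds, is whether an amine or a carboxylic acid on this aryl would give a step beyond the scatter. The rest of the core is the same in all three compounds, so its part in the read-out cannot be told.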